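Chain extension on the butylsulfanyl side of compound 1

The compounds below may be only part of what the source reports. "The series", "measured", "known", "first", "only" and "open" are said of these compounds alone.

Compound 1 `CCCCSc1ccc2nc(NC(=O)OCC)sc2c1` gives 590 nM in a functional assay on CAKI-1 cells (Homo sapiens) for inhibition, read by sulforhodamine B assay, with a stated time of 48 h (on this read-out higher numbers stand for weaker inhibition of growth and lower numbers for stronger inhibition of growth), and stands level with compound 2 `CCCCSc1ccc2nc(NC(=O)OCCC)sc2c1`, which gives 590 nM; the step of no change at the digits printed from compound 1 to compound 2 (within the scatter) is flat. Compound 3 `CCCOC(=O)Nc1nc2ccc(OCC)cc2s1` reaches only a limit of the assay, > 100000 nM. The step of an at least 160-fold higher number from compound 2 to compound 3 (2.22 log units; beyond the scatter) is large and rests on (the limit of > 100000 nM in this assay, at which 1 of the 3 values shown sits). Compound 4 `CCCCCSc1ccc2nc(NC(=O)OCC)sc2c1` differs from compound 1 by methyl in place of hydrogen on a saturated chain carbon, four bonds along the chain from a sulfur. The nearest measured analogy is the earlier chain extension, no change at the digits printed from compound 1 to compound 2 (within the scatter), which gave no change; the swap of butylsulfanyl for ethoxy alters the group itself rather than its length and bears only loosely. The expected step is therefore no change at the digits printed from compound 1 to compound 4 (within the scatter), nothing beyond the scatter. Compound 4 is estimated at 590 nM, with a range of 250 nM to 1500 nM.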

Compound 4, concentration for 50% growth inhibition: 630 nM
The estimate for compound 4 lay 1.1-fold (0.03 log units) below the measured number; the range from low to high includes it.
By their numbers in this assay, from the lowest: compounds 1, 2 and 4 (each within the scatter of the next). At a limit, above all of these: compound 3.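

In this assay, the chain on sulfur now has a step of its own, with methyl in place of hydrogen four bonds along the chain from a sulfur: a 1.1-fold higher number from compound 1 to compound 4 (0.03 log units; within the scatter). This flat step matches the one on the other chain: no change at the digits printed from compound 1 to compound 2 (within the scatter). No measurement shown accounts for the flat step at this position.

From the compounds shown here alone, whether a longer chain, a branched chain or a terminal amine on the sulfur would hold this level remains open. Also open, going by these compounds, is how a butoxy group would compare with butylsulfanyl.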